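The source may report more compounds than this note shows. Statements on the series, on what has been measured and on what is new or still open speak of the compounds shown alone.

Compound 1 `CC#C[C@H]1CN(S(=O)(=O)c2ccc(N)nc2)CCN1c1ccc(S(=O)(=NC)C(F)(F)F)cc1`: 2060 nM
Compound 2 `C#CCC(O)(c1ccc(N2CCN(S(=O)(=O)c3ccc(N)nc3)C[C@@H]2C#CC)cc1)C(F)(F)F`: 130 nM
Compound 3 `CC#C[C@H]1CN(S(=O)(=O)c2ccc(N)nc2)CCN1c1ccc(S(=O)(=O)Nc2ccccc2)cc1`: > 12500 nM

In an assay on cells (Hepatocyte) for inhibition of glucokinase regulatory protein (Mus musculus), with stated times of 20 min and 40 min (on this read-out lower numbers stand for an effect already at smaller amounts and higher numbers for an effect only at larger amounts of compound), compound 3 reaches only a limit, > 12500 nM, and no number. Compound 1 gives 2060 nM in this assay, and compound 2 gives 130 nM. Compound 3 therefore stands weakest of the three, as the steps of an at least 6.0-fold higher number from compound 1 to compound 3 (0.78 log units; beyond the scatter) and an at least 96-fold higher number from compound 2 to compound 3 (1.98 log units; beyond the scatter) show. Compound 4 `CC#C[C@H]1CN(S(=O)(=O)c2ccc(N)nc2)CCN1c1ccc(C(O)(COC)C(F)(F)F)cc1` carries the change (a group of 9 heavy atoms (4 carbon, 2 oxygen, 3 fluorine; no ring) in place of a group of 10 heavy atoms (6 carbon, 1 nitrogen, 2 oxygen, 1 sulfur; one six-membered aromatic ring of carbon only), on an aromatic carbon); what enters has no ring and carries the trifluoromethyl and hydroxyl groups that the group in compound 2 also carries, whereas the phenylsulfamoyl group leaves. Because an at least 96-fold higher number from compound 2 to compound 3 (1.98 log units; beyond the scatter) was large, a large step downward is expected for compound 4, an at least 50-fold lower number from compound 3 to compound 4 (1.69 log units; beyond the scatter). Compound 4 is estimated at 250 nM, within 60 nM to 1200 nM.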

Compound 4, half-maximal effective concentration: 202 nM
For compound 4 the middle estimate is 1.2-fold (0.09 log units) above the measured one; the measured number falls inside the stated range.
By their numbers in this assay, from the lowest: compounds 2 and 4 (each within the scatter of the next); then compound 1. At a limit, above all of these: compound 3.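

In this assay compound 3 gives only a limit and no number. The ring-free group carrying trifluoromethyl and hydroxyl on this aromatic carbon again gives a clear gain (an at least 61-fold lower number from compound 3 to compound 4 (1.79 log units; beyond the scatter)) and (a 10-fold lower number from compound 1 to compound 4 (1.01 log units; beyond the scatter)). Its ethynyl end is not essential, since methoxy in that place leaves compounds 2 and 4 indistinguishable (a 1.6-fold higher number from compound 2 to compound 4 (0.19 log units; within the scatter)). Still open, as far as these compounds go, is whether the hydroxyl itself matters, or whether an amine or a carboxylic acid could replace it. A longer chain in place of the methoxy is also untested in the compounds shown.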